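Dropping One Trifluoromethyl Group from Compound 3

The compounds below may be only part of what the source reports. "The series", "measured", "known", "first", "only" and "open" are said of these compounds alone.

Compound 1 `O=C(Nc1cccc(-n2cc(-c3ccncc3)c(-c3cc(O)cc(Cl)c3)n2)c1)Nc1ccc(Cl)c(C(F)(F)F)c1` gives 84% in a functional assay on 786-0 cells (Homo sapiens) for inhibition, read by sulforhodamine B assay, with a stated time of 48 h, tested at 1 uM (on this read-out lower numbers stand for a stronger effect and higher numbers for a weaker effect at the one concentration tested), and compound 2 `O=C(Nc1cccc(-n2cc(-c3ccncc3)c(-c3cc(O)cc(Cl)c3)n2)c1)Nc1ccc(Cl)c(Cl)c1` gives 71%. Compound 3 `COc1cc(Cl)cc(-c2nn(-c3cccc(NC(=O)Nc4cc(C(F)(F)F)cc(C(F)(F)F)c4)c3)cc2-c2ccncc2)c1` gives 38%, the lowest of the three numbers, and its gaps to compound 2 and to compound 1 both lie beyond the scatter. Compound 4 `COc1cc(Cl)cc(-c2nn(-c3cccc(NC(=O)Nc4cccc(C(F)(F)F)c4)c3)cc2-c2ccncc2)c1` is compound 3 with hydrogen in place of trifluoromethyl on an aromatic carbon. Among the measured compounds shown here, the only measured step that touches the same region of the molecule is a number 13 percentage points lower from compound 1 to compound 2 (beyond the scatter), where a trifluoromethyl also gave way, though to chloro rather than to hydrogen. That single step is loose ground, so a step of a number 12 percentage points higher from compound 3 to compound 4 (beyond the scatter) is expected, with the direction not settled. Compound 4 is therefore estimated at 50%, with a range from 35% to 70%.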

Compound 4, a percentage reported as activity, at one concentration (the size of the read-out at that concentration, not a potency): 77%
Beside the measured number, compound 4's estimate is 27 percentage points below it; measured number outside the range, above it.
By their numbers in this assay, from the lowest: compound 3; then compounds 2, 4 and 1 (each within the scatter of the next, the first and the last beyond it).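

In this assay, hydrogen in place of trifluoromethyl gives a number 39 percentage points higher from compound 3 to compound 4 (beyond the scatter), so at this carbon, meta to a trifluoromethyl group, a large part of the effect at the one concentration tested goes with the group. The earlier step, a number 13 percentage points lower from compound 1 to compound 2 (beyond the scatter), swapped trifluoromethyl for chloro and so never showed a ring carbon left with hydrogen. Nothing available explains this loss. On these data alone, whether a nitrile or an amine on this carbon would keep the effect of compound 3 remains open.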